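The compounds below may be only part of what the source reports. "The series", "measured", "known", "first", "only" and "open" are said of these compounds alone.

In an ADME assay (liver) for metabolic stability, with Liver microsome (Rattus norvegicus) as the target, using microsomes and NADPH, with a stated time of 30 min, tested at 1 uM (on this read-out lower numbers stand for slow clearance and higher numbers for fast clearance), three compounds sharing one core have been measured. Compound 1 `Nc1ccc(S(=O)(=O)N2CCN(c3ncc(C(O)(C(F)(F)F)C(F)(F)F)cc3C3CC3)CC2)cn1`, with a cyclopropyl group on an aromatic carbon, gives 27 mL.min-1.g-1. Compound 2 `CC(C)n1cc(-c2cc(C(O)(C(F)(F)F)C(F)(F)F)cnc2N2CCN(S(=O)(=O)c3ccc(N)nc3)CC2)cn1`, with 1-isopropyl-1H-pyrazol-4-yl in that place, gives 198 mL.min-1.g-1. Compound 3 `CS(=O)(=O)c1ccc(-c2cc(C(O)(C(F)(F)F)C(F)(F)F)cnc2N2CCN(S(=O)(=O)c3ccc(N)nc3)CC2)cc1`, with 4-(methylsulfonyl)phenyl there, gives 103 mL.min-1.g-1. On these numbers, compound 3 cannot be told apart from compound 2, and both stand above compound 1.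

Compound 4 `Nc1ccc(S(=O)(=O)N2CCN(c3ncc(C(O)(C(F)(F)F)C(F)(F)F)cc3-c3cnccc3F)CC2)cn1` keeps the core and changes that same group: 4-fluoropyridin-3-yl in place of 4-(methylsulfonyl)phenyl on an aromatic carbon. In words, 4-fluoropyridin-3-yl comes in place of 4-(methylsulfonyl)phenyl on an aromatic carbon.

Among the measured compounds shown here, no measured compound carries the entering group, so the evidence is indirect. Two steps away from cyclopropyl were modest, a 7.3-fold higher number from compound 1 to compound 2 (0.87 log units; beyond the scatter) and a 3.8-fold higher number from compound 1 to compound 3 (0.58 log units; beyond the scatter). The swap between the two aromatic groups was smaller, a 1.9-fold lower number from compound 2 to compound 3 (0.28 log units; within the scatter), and stayed within the scatter. That swap is the closest parallel, as it too exchanges one aromatic group for another, so no large change is expected here. The direction remains uncertain, with a slight drop towards compound 1 at 27 mL.min-1.g-1 considered the more likely outcome. The expected change is a 1.5-fold lower number from compound 3 to compound 4 (0.17 log units; within the scatter), which is not expected to go beyond the scatter. For compound 4, the estimated value in this assay is 70 mL.min-1.g-1, with an expected range of 28 mL.min-1.g-1 to 170 mL.min-1.g-1.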

Compound 4, intrinsic clearance in microsomes: 22 mL.min-1.g-1
The estimate for compound 4 lay 3.2-fold (0.50 log units) above the measured number, and the stated range ends above it.
By their numbers in this assay, from the lowest: compounds 4 and 1 (each within the scatter of the next); then compounds 3 and 2 (each within the scatter of the next).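

At this position, on an aromatic carbon ortho to a large group, in this assay, an aromatic ring does not by itself go with a high number: the change to 4-fluoropyridin-3-yl gives a 4.7-fold lower number from compound 3 to compound 4 (0.67 log units; beyond the scatter) and a 9.0-fold lower number from compound 2 to compound 4 (0.95 log units; beyond the scatter), whereas the earlier swap between two aromatic groups had stayed within the scatter. The same group also gives a 1.2-fold lower number from compound 1 to compound 4 (0.09 log units; within the scatter), so 4-fluoropyridin-3-yl cannot be told apart from cyclopropyl here, and the earlier gap between cyclopropyl and the aromatic groups now holds for only two of the three aromatic groups shown. Nothing available explains why this aromatic group differs from the other two.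

The compounds shown leave open whether the ring nitrogen, the fluorine or the two together go with the lower number, a question that a plain pyridin-3-yl or a 4-fluorophenyl group at this carbon could separate. On these data alone, it also remains open whether another kind of group here, such as an amine like morpholine, could bring the number clearly under those of compound 1 and compound 4.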